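Moving one hydroxyl: what compound 4 may show

This account rests on a few compounds, and the source may have more. Where it says the series, first, only, none or still open, it means among the compounds named here.

Compound 1 `Oc1ccccc1-c1cc(-c2cccc(OC(F)(F)F)c2)cc(-c2ccccc2O)n1` gives 7470 nM in a functional assay on DU-145 cells (Homo sapiens) for inhibition; a higher number here means a weaker inhibitor, a lower number a stronger inhibitor.
Compound 2 `Oc1ccccc1-c1cc(-c2ccc(OC(F)(F)F)cc2)cc(-c2ccccc2O)n1` gives 20300 nM in this assay.
Compound 3 `Oc1cccc(-c2cc(-c3cccc(OC(F)(F)F)c3)cc(-c3ccccc3O)n2)c1` reaches only a limit of the assay in this assay, reported as > 50000 nM.

Among the two numbered values, compound 2 stands higher than compound 1, and that gap lies beyond the usual scatter. How the cores of compound 1 and compound 2 differ is not broken down here. Going by the values given here, the single change from compound 1 to compound 3 is 3-hydroxyphenyl in place of 2-hydroxyphenyl on an aromatic carbon and carries an at least 6.6-fold higher number from compound 1 to compound 3 (0.82 log units; beyond the scatter), a step that ends at a limit, as the limit of > 50000 nM in this assay, at which 1 of the 3 values shown sits, records.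

Compound 4 `Oc1cccc(-c2cc(-c3ccc(OC(F)(F)F)cc3)cc(-c3ccccc3O)n2)c1` has not yet been measured. It differs from compound 2 by 3-hydroxyphenyl in place of 2-hydroxyphenyl on an aromatic carbon, the same change that separates compound 1 from compound 3. Because compound 2 already starts from 20300 nM, a step of the size of an at least 6.6-fold higher number from compound 1 to compound 3 (0.82 log units; beyond the scatter) is expected to carry compound 4 past the limit of the assay. The expected step is a 5.9-fold higher number from compound 2 to compound 4 (0.77 log units; beyond the scatter). For compound 4 the estimated value is 120000 nM, with a likely range from 50000 nM to 400000 nM, most probably reported only as a limit.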

Compound 4, half-maximal inhibitory concentration: 21100 nM
Estimate against measurement, compound 4: 5.7-fold (0.75 log units) above; the measured number lies below the stated range.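

In this assay, the exchange of 2-hydroxyphenyl for 3-hydroxyphenyl on the core of compound 2 gives a 1.0-fold higher number from compound 2 to compound 4 (0.02 log units; within the scatter), so on this core the change leaves the number where it was. The same change therefore does not carry over in size from the core of compound 1 to the core of compound 2, and the two steps differ clearly: the same change on two cores in this assay, an at least 6.6-fold higher number (0.82 log units; beyond the scatter) from compound 1 to compound 3 and a 1.0-fold higher number (0.02 log units; within the scatter) from compound 2 to compound 4, at least 6.4-fold (0.80 log units) apart, beyond the scatter of two such steps. The value of compound 3 is a limit and not a number, and two cores alone do not show which difference between them decides the outcome: the limit of > 50000 nM in this assay, at which 1 of the 4 values shown sits.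

The compounds shown leave open how the same exchange would behave on a core with a methoxy group or a chlorine in place of the trifluoromethoxy group. They also leave open whether an aminophenyl group in place of the hydroxyphenyl group would follow compound 3 or compound 4 in this assay.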